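A few compounds are considered here, and "the series" means these few. Any claim that something is new, unique, unknown or untested is made for them only; others in the source may bear on it.

Measured compounds:
- compound 1 `COc1ccc(-c2cc3c(OC)cc(OC)cc3n(C)c2=O)cc1` — 10000 nM
- compound 2 `COc1ccc(-c2cc3c(OC)cc(OC)cc3n(CC#N)c2=O)cc1` — 10000 nM
- compound 3 `COc1ccc(-c2cc3c(OC)cc(OC)cc3n(CCCC#N)c2=O)cc1` — 10000 nM

In a functional assay on A549 cells (Homo sapiens) for cytotoxicity, read by colorimetric assay and MTT assay (on this read-out lower numbers stand for stronger inhibition and higher numbers for weaker inhibition), compound 1 stands level with the other two: no change at the digits printed from compound 1 to compound 2 (within the scatter), no change at the digits printed from compound 1 to compound 3 (within the scatter), and no change at the digits printed from compound 2 to compound 3 (within the scatter). Every one of these changes sits on the saturated chain carbon bound to the aromatic nitrogen, and none of them moved the read-out beyond the scatter of repeated measurements.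

Compound 4 `COc1cc(OC)c2cc(-c3ccc(OC(C)=O)cc3)c(=O)n(C)c2c1` is not yet measured. It differs from compound 1 at a different place, the oxygen on the aromatic ring: acetyl in place of methyl on an oxygen on an aromatic ring. Among the compounds with values here, no measured pair touches this oxygen, so the three steps above give no direct guide to what this change does; they show only that the shared core of compound 1, with its substituents so far varied, has not left the common level in this assay.

With nothing in the data pointing to a shift, the step from compound 1 to compound 4 is expected to be no change at the digits printed from compound 1 to compound 4 (within the scatter), that is, none beyond the scatter. Compound 4 is therefore estimated at 10000 nM, with a range from 5000 nM to 20000 nM.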

Compound 4, half-maximal inhibitory concentration: 10000 nM
Compound 4: middle estimate and measured number agree at the digits printed; low and high end bracket the measured number.
By their numbers in this assay, from the lowest: compounds 1, 2, 3 and 4 (each within the scatter of the next).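

Within the data shown here, this is the first change at the oxygen on an aromatic ring rather than on the chain at the aromatic nitrogen, and in this assay going from methoxy to acetoxy gives no change at the digits printed from compound 1 to compound 4 (within the scatter) at this position. Acetyl has more heavy atoms than methyl and brings a hydrogen-bond acceptor and a double bond that methyl lacks, yet neither difference shows in the read-out here. The data offer no explanation for this flat result.

All four compounds stand level, so no change shown so far separates one from another in this cytotoxicity read-out. Still open, on these data alone, is whether a free hydroxyl, an amine or a longer ester chain on this oxygen, or a carboxylic acid elsewhere on the shared core, would give a different number.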